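Aryl Swap on the Amine Nitrogen: Compound 2 to Compound 4

The source may hold more compounds than are shown below. What is called first, only, known or untested is meant among the compounds shown, and "the series" means these compounds.

Compound 1, `COc1cc(NC(=O)Nc2cc(Nc3ccc(C(C)(C)C)cc3)ncn2)cc(OC)c1`: 38.7%
Compound 2, `COc1cc(NC(=O)Nc2cc(Nc3ccc(C)c(C)c3)ncn2)cc(OC)c1`: 20.1%
Compound 3, `Cc1cc(F)cc(Nc2cc(NC(=O)Nc3c(Cl)cccc3Cl)ncn2)c1`: 65.1%

In a functional assay on NCI-H1581 cells (Homo sapiens) for inhibition, read by MTT assay, with a stated time of 48 h, tested at 10 uM (on this read-out lower numbers stand for less inhibition and higher numbers for more inhibition at the one concentration tested (going by the name of the read-out)), compound 2 stands lowest of the three numbers. Its nearest neighbour is reached by the step of a number 18.6 percentage points lower from compound 1 to compound 2 (beyond the scatter), a modest fall, while compound 3 lies further away at 65.1%. Compound 4, `CCc1cccc(Nc2cc(NC(=O)Nc3cc(OC)cc(OC)c3)ncn2)c1`, is not yet measured; it differs from compound 2 by 3-ethylphenyl in place of 3,4-dimethylphenyl on a nitrogen on an aromatic ring. For the measured compounds named here, the only measured step on the same nitrogen is a number 18.6 percentage points lower from compound 1 to compound 2 (beyond the scatter), and no measured compound carries 3-ethylphenyl, so its effect is untested. Compound 4 is therefore expected to sit close to compound 2, with a step of a number 4.9 percentage points higher from compound 2 to compound 4 (within the scatter) that may not exceed the scatter. The estimate for compound 4 is 25%, within 10% to 45%.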

Compound 4, a percentage reported as inhibition, at one concentration (the size of the read-out at that concentration, not a potency): 27.7%
Beside the measured number, compound 4's estimate is 2.7 percentage points below it; the measured number falls inside the stated range.
By their numbers in this assay, from the lowest: compounds 2 and 4 (each within the scatter of the next); then compound 1; then compound 3.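

In this assay, rearranging the same eight carbons on the nitrogen, from 3,4-dimethylphenyl to 3-ethylphenyl, gives a number 7.6 percentage points higher from compound 2 to compound 4 (within the scatter), so this change does not separate the two compounds. The second comparison, a number 11 percentage points lower from compound 1 to compound 4 (beyond the scatter), shows that 3-ethylphenyl, like 3,4-dimethylphenyl, does not match 4-(tert-butyl)phenyl at this position. No supporting data bear on why these numbers differ.

From the compounds shown here alone, only hydrocarbon groups on the phenyl ring appear at this nitrogen, so it remains open how a methoxy group, an amine or a carboxylic acid there would read.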